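Compound 2 to Compound 3: Changing the Amide-Side Ring

The source may hold more compounds than are shown below. What is called first, only, known or untested is meant among the compounds shown, and "the series" means these compounds.

Measured so far:
compound 1, `O=C(NCc1ccc(S(=O)(=O)N2CCCCC2)cc1)c1cnc2nccn2c1`, 3 nM
compound 2, `O=C(NCc1ccc(S(=O)(=O)c2cc(F)cc(F)c2)cc1)c1cnc2nccn2c1`, 2 nM

Among the measured compounds shown here, in an assay for inhibition of Nicotinamide phosphoribosyltransferase (Homo sapiens), read by mass spectrometry, with stated times of 15 min and 30 min (on this read-out higher numbers stand for weaker inhibition and lower numbers for stronger inhibition), compound 2 gives 2 nM, the lowest of the two numbers, and its only neighbour is compound 1. For the measured compounds named here, the single measured step, a 1.5-fold lower number from compound 1 to compound 2 (0.18 log units; within the scatter), lies within the scatter. Compound 3, `O=C(NCc1ccc(S(=O)(=O)c2cc(F)cc(F)c2)cc1)c1cc2ccncc2o1`, differs from compound 2 by a group of 9 heavy atoms (7 carbon, 1 nitrogen, 1 oxygen; one five-membered aromatic ring with 1 hetero atom, one six-membered aromatic ring with 1 hetero atom) in place of a group of 9 heavy atoms (6 carbon, 3 nitrogen; one five-membered aromatic ring with 2 hetero atoms, one six-membered aromatic ring with 2 hetero atoms), on a carbonyl carbon. The measured step alters the group on the sulfonyl sulfur, not the carbonyl side, so it bears on this change only as a sign that the shared core tolerates variation. No step beyond the scatter is therefore predicted, though the missing data widen the range. Compound 3 is estimated at 8 nM, between 2 nM and 40 nM. The expected step is a 4.0-fold higher number from compound 2 to compound 3 (0.60 log units; beyond the scatter).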

Compound 3, half-maximal inhibitory concentration: 14 nM
Compound 3: middle estimate off by 1.8-fold (0.24 log units), on the low side, and the stated range covers the measured number.
By their numbers in this assay, from the lowest: compounds 2 and 1 (each within the scatter of the next); then compound 3.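

In this assay, among the compounds shown here, a 7.0-fold higher number from compound 2 to compound 3 (0.85 log units; beyond the scatter) is the first step here to lie beyond the scatter, so the group on the carbonyl carbon changes the number measurably, whereas the one earlier change, on the sulfonyl sulfur, did not. The entering and leaving groups have the same ring sizes and heavy-atom count, so a change in ring atoms alone is enough to produce a modest step. Nothing available here explains this shift.

As far as these compounds go, it remains open which ring atom accounts for the step, and whether it would recur with piperidin-1-yl on the sulfonyl sulfur. Also open, from the compounds shown here alone, is how a single pyridin-3-yl ring on the carbonyl carbon would compare.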